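Swapping the aryl group on the saturated ring carbon

The source may report more compounds than this note shows. Statements on the series, on what has been measured and on what is new or still open speak of the compounds shown alone.

Compound 1 `O=C1N=C(N2N=C(c3ccccc3)CC2c2ccccc2O)S/C1=C1/C(=O)Nc2ccccc21` gives the highest number of the three measured compounds in a functional assay on cells (Cancer cell lines, Homo sapiens) for cytotoxicity, read by sulforhodamine B assay, with a stated time of 48 h (on this read-out lower numbers stand for stronger inhibition of growth and higher numbers for weaker inhibition of growth), with 4730 nM. Compound 2 `O=C1N=C(N2N=C(c3ccccc3)CC2c2ccccc2O)S/C1=C1/C(=O)Nc2ccc(Br)cc21` reaches 670 nM, and compound 3 `COc1ccc(C2CC(c3ccc4ccccc4c3)=NN2C2=NC(=O)/C(=C3\C(=O)Nc4ccc(Br)cc43)S2)cc1` reaches 220 nM. Among the measured compounds shown here, the only single-point step measured, a 7.1-fold lower number from compound 1 to compound 2 (0.85 log units; beyond the scatter), concerns bromo in place of hydrogen on an aromatic carbon and leaves untouched the group that changes here. Compound 4 `CN(C)c1ccc(C2CC(c3ccccc3)=NN2C2=NC(=O)/C(=C3\C(=O)Nc4ccccc43)S2)cc1` differs from compound 1 by 4-(dimethylamino)phenyl in place of 2-hydroxyphenyl on a saturated ring carbon. No measured step bears on this exchange, so the expected step of a 1.4-fold lower number from compound 1 to compound 4 (0.13 log units; within the scatter) is small, and its direction cannot be read from the data shown. Compound 4 is therefore estimated at 3500 nM, within a range from 1000 nM to 12000 nM.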

Compound 4, concentration for total growth inhibition: 25200 nM
Estimate against measurement, compound 4: 7.2-fold (0.86 log units) below, outside the stated range (above it).
By their numbers in this assay, from the lowest: compound 3; then compound 2; then compound 1; then compound 4.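

In this assay, among the compounds shown here, the first measured change at this position gives a 5.3-fold higher number from compound 1 to compound 4 (0.73 log units; beyond the scatter), so the saturated ring carbon does not tolerate every aryl group equally. Compound 4 now has the highest number of the four compounds. No evidence shown explains this step. The exchange removes the 2-hydroxyphenyl group and introduces the 4-(dimethylamino)phenyl group in one step, so the contribution of each remains unresolved. Going by these compounds, how a plain phenyl group or a 4-hydroxyphenyl group would read at this carbon on the core of compound 1 remains open.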